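Replacing the fluorophenyl amide with an isobutyl amide

The compounds below may be only part of what the source reports. "The series", "measured", "known", "first", "only" and "open" are said of these compounds alone.

Compound 1, `CC(C)[C@@H](NC(=O)CCc1ccc(F)cc1)C(=O)N1CCC(c2ccc(Cl)cc2)CC1`: 70 nM
Compound 2, `CC(C)[C@@H](NC(=O)c1ccc(F)cc1)C(=O)N1CCC(c2ccc(Cl)cc2)CC1`: 118 nM

Both compounds share the same core and differ only in the group on the carbonyl carbon of the amide. In an assay on THP-1 cells for displacement of a labelled ligand from C-C chemokine receptor type 1 (Homo sapiens) (on this read-out lower numbers stand for stronger inhibition and higher numbers for weaker inhibition), compound 2 gives 118 nM, the higher of the two numbers; the gap a 1.7-fold higher number from compound 1 to compound 2 (0.23 log units; within the scatter) lies within the scatter, so the two compounds cannot be told apart on this read-out.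

Compound 3, `CC(C)CC(=O)N[C@@H](C(=O)N1CCC(c2ccc(Cl)cc2)CC1)C(C)C`, takes the change one step further: isobutyl in place of 4-fluorophenyl on a carbonyl carbon. The aromatic ring is gone and a short branched chain takes its place. For the measured compounds named here, only one measured step touches this position, a 1.7-fold higher number from compound 1 to compound 2 (0.23 log units; within the scatter), and it was small. It does not involve loss of the ring, so it gives only weak guidance. The expectation for compound 3 is therefore a modest rise in this assay, a 1.7-fold higher number from compound 2 to compound 3 (0.23 log units; within the scatter), with a wide range. Compound 3 is estimated at 200 nM, between 70 nM and 600 nM.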

Compound 3, half-maximal inhibitory concentration: 32 nM
Beside the measured number, compound 3's estimate is 6.3-fold (0.80 log units) above it, and the stated range ends above it.
By their numbers in this assay, from the lowest: compound 3; then compounds 1 and 2 (each within the scatter of the next).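

Removing the aromatic ring from this position does not cost binding in this assay: isobutyl in place of 4-fluorophenyl gives a 3.7-fold lower number from compound 2 to compound 3 (0.57 log units; beyond the scatter) and so moves the number the opposite way from the rise that the first step hinted at. Compound 3 also stands apart from the compound with the longer ring-bearing chain, with a 2.2-fold lower number from compound 1 to compound 3 (0.34 log units; beyond the scatter) for the change printed for that pair. Compounds 1 and 2 could not be told apart, so only compound 3 shows that the group on this carbonyl carbon can shift the number beyond the scatter, and that a ring is not required there. Nothing shown gives a reason for this gain.

A cyclohexyl group would show whether the ring itself or its aromatic character matters here. An ethyl group or a longer branched chain would show how far the number depends on the size of the chain.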